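This account rests on a few compounds, and the source may have more. Where it says the series, first, only, none or still open, it means among the compounds named here.

Measured compounds:

Compound 1, `Fc1ccc(CNc2nc(Nc3cc(C4CC4)[nH]n3)c3ccccc3n2)c(F)c1`: 4.7 nM
Compound 2, `Fc1ccc(CNc2nc(Nc3cc(C4CC4)[nH]n3)c3ccc(Br)cc3n2)c(F)c1`: 150 nM
Compound 3, `Cc1cc(Nc2nc(NCc3ccc(F)cc3F)nc3cc(C(F)(F)F)ccc23)n[nH]1`: 57 nM

In an assay for inhibition of high affinity nerve growth factor receptor (Homo sapiens), read by HTRF, with a stated time of 30 min, in the presence of a further agent that is not named here (a lower number here means a stronger inhibitor, a higher number a weaker inhibitor), compound 3 stands second highest of the three numbers; its nearest neighbour is compound 2, and its furthest is compound 1. Within the data shown here, the only step between two compounds that differ in a single place is a 32-fold higher number from compound 1 to compound 2 (1.50 log units; beyond the scatter), which concerns a different position and shows that a change on that aromatic carbon of the shared core can move the number a great deal. Among the measured compounds shown here, compound 4, `Fc1ccc(CNc2nc(Nc3cc(C4CC4)[nH]n3)c3ccc(C(F)(F)F)cc3n2)c(F)c1`, differs from compound 3 by cyclopropyl in place of methyl on an aromatic carbon, and no measured pair isolates this change, so the measured steps bear on it only indirectly. Compound 1 and compound 3 differ in more than one place, so their values cannot be split between the two changes. For the measured compounds named here, with no direct precedent, the step in this assay from compound 3 to compound 4 is expected to be small, as a 1.4-fold lower number from compound 3 to compound 4 (0.15 log units; within the scatter), and compound 4 is estimated at 40 nM, between 12 nM and 130 nM.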

Compound 4, half-maximal inhibitory concentration: 17 nM
The estimate for compound 4 lay 2.4-fold (0.37 log units) above the measured number; the range from low to high includes it.
By their numbers in this assay, from the lowest: compound 1; then compound 4; then compound 3; then compound 2.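

In this assay, among these compounds, cyclopropyl in place of methyl on the aromatic carbon of the five-membered ring gives a 3.4-fold lower number from compound 3 to compound 4 (0.53 log units; beyond the scatter) and so shows, through the first pair to isolate this change, that this position responds beyond the scatter. With cyclopropyl held fixed on the shared core, trifluoromethyl in place of hydrogen gives a 3.6-fold higher number from compound 1 to compound 4 (0.56 log units; beyond the scatter) and trifluoromethyl in place of bromo gives an 8.8-fold lower number from compound 2 to compound 4 (0.95 log units; beyond the scatter), so at that aromatic carbon of the core, hydrogen gives the lowest number of the three and trifluoromethyl falls short of it while still beating bromo. Nothing measured here explains the size of these steps.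

From the compounds shown here alone, whether a cyclobutyl or an amine on the five-membered ring would lower the number further remains open. So does whether a methoxy or a carboxylic acid on the core could match hydrogen there.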